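Swapping the aryl amine in a urea series

A few compounds are considered here, and "the series" means these few. Any claim that something is new, unique, unknown or untested is made for them only; others in the source may bear on it.

Measured so far:
compound 1 `COc1ccc(F)cc1Nc1cc(NC(=O)Nc2c(Cl)cccc2Cl)ncn1` gives 78%;
compound 2 `COc1cc(NC(=O)Nc2cc(Nc3ccc(F)c(Cl)c3)ncn2)cc(OC)c1` gives 53.1%;
compound 3 `COc1cc(NC(=O)Nc2cc(Nc3cc(Br)ccc3OC)ncn2)cc(OC)c1` gives 76.3%.

In a functional assay on HCC827 cells (Homo sapiens) for inhibition, read by MTT assay, with a stated time of 48 h, tested at 10 uM (on this read-out higher numbers stand for more inhibition at the one concentration tested (going by the name of the read-out) and lower numbers for less inhibition), compound 1 holds the highest of the three numbers; compound 3 sits within the scatter of it, while compound 2 lies beyond the scatter below it. Compound 4 `CCc1ccc(Nc2cc(NC(=O)Nc3c(Cl)cccc3Cl)ncn2)cc1` differs from compound 1 in one place: 4-ethylphenyl in place of 5-fluoro-2-methoxyphenyl on a nitrogen on an aromatic ring. Going by the values given here, the one measured step at that nitrogen, a number 23.2 percentage points higher from compound 2 to compound 3 (beyond the scatter), saw a methoxy-bearing aryl enter and the number rise. Compound 4 moves the other way, losing the methoxy-bearing aryl, so a fall in this assay beyond the scatter is expected, though smaller than the reverse of that step since compound 2 also carries no methoxy there. Compound 4 is estimated at 58% in this assay, between 40% and 76%, a step of a number 20 percentage points lower from compound 1 to compound 4 (beyond the scatter).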

Compound 4, a percentage reported as inhibition, at one concentration (the size of the read-out at that concentration, not a potency): 58%
Compound 4: the middle estimate sits on the measured number at the digits printed, within the range that was stated.
By their numbers in this assay, from the lowest: compounds 2 and 4 (each within the scatter of the next); then compounds 3 and 1 (each within the scatter of the next).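

In this assay, exchanging the methoxy-bearing aryl on this nitrogen for 4-ethylphenyl gives a number 20 percentage points lower from compound 1 to compound 4 (beyond the scatter), so the fall now appears on a second urea partner and agrees in direction with a number 23.2 percentage points higher from compound 2 to compound 3 (beyond the scatter), where a methoxy-bearing aryl entered. Going by these compounds alone, the change replaces an aryl carrying oxygen and fluorine, with one hydrogen-bond acceptor, by an all-carbon aryl with none, so the single step cannot separate the contribution of each atom. No evidence given here accounts for the fall. Still open, from the compounds shown here alone, is whether a methoxyphenyl lacking the fluorine would keep the higher number, and how an aryl bearing an amine or a carboxylic acid on this nitrogen would read.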